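The source may report more compounds than this note shows. Statements on the series, on what has been measured and on what is new or still open speak of the compounds shown alone.

Compound 1 `CC(=O)c1ccc(Nc2c(C(C)=O)sc(NC(=O)CC#N)c2C#N)cc1`: 56100 nM
Compound 2 `CC(=O)c1ccc(Nc2c(C(=O)/C=C/c3ccccc3)sc(/N=C/c3ccccc3)c2C#N)cc1`: 19100 nM; 26200 nM (2 entries)

Both compounds were tested in a functional assay on HepG2 cells (Homo sapiens) for inhibition, read by MTT assay, with a stated time of 48 h; on this read-out higher numbers stand for weaker inhibition and lower numbers for stronger inhibition. Within the data shown here, there, compound 1 gives 56100 nM, the only number it has, and one further entry for it carries no single number. This number is higher than both entries for compound 2, which means weaker inhibition on this read-out. How far repeat measurements can lie apart is seen in the several entries of compound 2 in this assay, 19100 nM; 26200 nM (2 entries).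

The next compound is compound 3 `CC(=O)Nc1sc(C(C)=O)c(Nc2ccc(C(C)=O)cc2)c1C#N`, still unmeasured. It keeps the core of compound 1 and differs in one place: hydrogen in place of cyano on a saturated chain carbon bound to a carbonyl carbon. Put simply, hydrogen takes the place of cyano on a saturated chain carbon bound to a carbonyl carbon, turning ((cyanomethyl)carbonyl)amino into acetamido.

Among the measured compounds shown here, no pair of measured compounds differs in only one place, and the data offer no direct guide to this change. The expectation in this assay is therefore no shift beyond the usual scatter, in either direction, with compound 1 at 56100 nM as the anchor. The expected change is a 1.2-fold lower number from compound 1 to compound 3 (0.10 log units; within the scatter). For compound 3 the estimated value is 45000 nM, with an expected range from 15000 nM to 120000 nM.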

Compound 3, half-maximal inhibitory concentration: 66200 nM
The estimate for compound 3 lay 1.5-fold (0.17 log units) below the measured number; the range from low to high includes it.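

In this assay, among these compounds, the change from cyano to hydrogen on a saturated chain carbon bound to a carbonyl carbon gives a 1.2-fold higher number from compound 1 to compound 3 (0.07 log units; within the scatter) and is the first step here between two measured compounds that differ in one place. It shows that, on this read-out, the cyanomethyl group of the ((cyanomethyl)carbonyl)amino side chain can give way to the methyl of acetamido with no shift that can be told from noise, so the nitrile at this position is not needed to hold the number where it stands. Repeat entries for one compound lie at least as far apart as this step, as seen in: the several entries of compound 2 in this assay, 19100 nM; 26200 nM (2 entries).

What the compounds shown leave open is whether other groups on this chain carbon, such as an amine, a carboxylic acid or a longer chain like propyl, would move the number beyond the scatter. They also leave open whether the same change from cyano to hydrogen would read alike on a compound that differs from compound 1 elsewhere on the shared core.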